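Aryl swap from compound 2 to compound 4

A few compounds are considered here, and "the series" means these few. Any claim that something is new, unique, unknown or untested is made for them only; others in the source may bear on it.

Measured in a functional assay on CAL-51 cells (Homo sapiens) for inhibition, read by sulforhodamine B assay, with a stated time of 3 days; a higher number here means a weaker inhibitor of growth, a lower number a stronger inhibitor of growth:
compound 1 `O=C(/C=C/c1ccc(Cl)cc1)c1ccccc1` gives 5850 nM
compound 2 `O=C(/C=C/c1ccccc1Cl)c1ccc(OCc2ccccc2)cc1` gives 7100 nM
compound 3 `O=C(/C=C/c1ccc(F)cc1)c1ccccc1` gives 2780 nM

Compound 2 holds the highest of the three numbers. Compound 1 is nearest, within the scatter, so no order between compound 2 and compound 1 can be stated. Compound 3 is furthest, beyond the scatter. Within the data shown here, the only step measured in one place is a 2.1-fold lower number from compound 1 to compound 3 (0.32 log units; beyond the scatter), fluoro in place of chloro on an aromatic carbon.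

Compound 4 `COc1ccc(/C=C/C(=O)c2ccc(OCc3ccccc3)cc2)cc1` differs from compound 2 by 4-methoxyphenyl in place of 2-chlorophenyl on a double-bonded chain carbon bound to a double-bonded chain carbon. Among the measured compounds shown here, no measured pair puts methoxy in place of chloro, and no measured pair moves a group from one aromatic carbon to another; the step from compound 1 to compound 3 is the sole change on the ring carried by the double-bonded chain, and it is a different kind of change. The direction is therefore open, and no step beyond the scatter is firmly expected in this assay. Compound 4 is estimated at 5000 nM, with a range of 1800 nM to 14000 nM. That estimate means an expected step of a 1.4-fold lower number from compound 2 to compound 4 (0.15 log units; within the scatter).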

Compound 4, concentration for 50% growth inhibition: > 50000 nM
Compound 4: only a limit was reported; the forecaster's own chance of this, stated with the estimate: 5%; at least 10-fold (1.00 log units) between middle value and limit.
By their numbers in this assay, from the lowest: compound 3; then compounds 1 and 2 (each within the scatter of the next). At a limit, above all of these: compound 4.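

Compound 4 is reported only as a limit in this assay: the limit of > 50000 nM in this assay, at which 1 of the 4 values shown sits. Even so, the step can be read, and 4-methoxyphenyl in place of 2-chlorophenyl gives an at least 7.0-fold higher number from compound 2 to compound 4 (0.84 log units; beyond the scatter). The earlier compounds shown here showed only a halogen exchange on this ring, a 2.1-fold lower number from compound 1 to compound 3 (0.32 log units; beyond the scatter), whereas this result shows that growth inhibition at this place, on a double-bonded chain carbon bound to a double-bonded chain carbon, can also fall out of the measured range with a change of group.

As far as these compounds go, whether the step follows from methoxy in place of chloro or from the different place of the group on the ring stays open, since the change covers both. From the compounds shown here alone, how a ring bearing an amine or a carboxylic acid on this same chain carbon would read in this assay is also open.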